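The source may hold more compounds than are shown below. What is called first, only, known or untested is meant among the compounds shown, and "the series" means these compounds.

Compound 1 `[N-]=[N+]=NCc1ncnc2c1ncn2[C@@H]1O[C@H](CO)[C@@H](O)[C@H]1O` carries an azido group on a saturated chain carbon bound to an aromatic carbon of the shared core. In a functional assay on Huh-7 cells (Homo sapiens) for cytotoxicity, read by MTT assay, with a stated time of 3 days (on this read-out lower numbers stand for higher toxicity in this test and higher numbers for lower toxicity in this test), compound 1 gives > 250000 nM, which is a limit of the assay rather than a number. Compound 2 `OC[C@H]1O[C@@H](n2cnc3c(Cn4ccc5ccccc54)ncnc32)[C@H](O)[C@@H]1O` also gives > 250000 nM, again a limit. Compound 3 `CN(Cc1ccccc1)Cc1ncnc2c1ncn2[C@@H]1O[C@H](CO)[C@@H](O)[C@H]1O` gives 9000 nM. The two limits make a step that the two limits leave unreadable from compound 1 to compound 2, while an at least 27-fold lower number from compound 1 to compound 3 (1.44 log units; beyond the scatter) and an at least 27-fold lower number from compound 2 to compound 3 (1.44 log units; beyond the scatter). Compound 4 `COCc1ncnc2c1ncn2[C@@H]1O[C@H](CO)[C@@H](O)[C@H]1O` differs from compound 1 by methoxy in place of azido on a saturated chain carbon bound to an aromatic carbon. Among the compounds with values here, of the measured steps, only the one from compound 1 to compound 3 brought a large shift, and it introduced a different group than methoxy; the step to the indolyl group stayed at the limit. Compound 4 is therefore expected to give about 250000 nM, likely between 80000 nM and 500000 nM. The expected step is a number no higher from compound 1 to compound 4 (the limit leaves the size open).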

Compound 4, half-maximal cytotoxic concentration: > 100000 nM
Compound 4 ended at the assay's limit; the forecaster's own chance of this, stated with the estimate: 70%; the middle value does not contradict the limit.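

Within the data shown here, with methoxy, three different groups on this saturated chain carbon bound to an aromatic carbon now give only limits, while benzyl(methyl)amino remains the one group with a readable number. In this assay, replacing that group with methoxy gives an at least 11-fold higher number from compound 3 to compound 4 (1.04 log units; beyond the scatter). The steps from compound 1 and compound 2 to compound 4 cannot be read because both ends of each are limits: the limit of > 100000 nM in this assay, at which 1 of the 4 values shown sits.

Going by these compounds, it remains open whether the benzyl or the methyl part of benzyl(methyl)amino matters for this shift. Also open, on these data alone, is whether a simple primary amine or a longer ether chain here would give a readable number.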